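The source may hold more compounds than are shown below. What is called first, only, known or untested is meant among the compounds shown, and "the series" means these compounds.

Measured so far:
compound 1, `COc1cc2nc(/C=C/c3cccnc3)nc(N3CCC(CCNS(N)(=O)=O)CC3)c2cc1OC`: 86%
compound 2, `COc1cccc(/C=C/c2nc(N3CCC(CCNS(N)(=O)=O)CC3)c3cc(OC)c(OC)cc3n2)c1`: 88%

Both numbers come from an assay on cells for inhibition of Ectonucleotide pyrophosphatase/phosphodiesterase family member 1 (Homo sapiens), with a stated time of 60 min, tested at 1 uM (a higher number here means more inhibition at the concentration tested (going by the name of the read-out), a lower number less inhibition), where compound 1 gives 86% and compound 2 gives 88%. Compound 1 has the lowest of the two numbers, but its nearest neighbour, compound 2, sits a number 2 percentage points higher from compound 1 to compound 2 (within the scatter), so the two are not separable.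

Compound 3, `COc1cc2nc(CCc3ccc(F)cc3)nc(N3CCC(CCNS(N)(=O)=O)CC3)c2cc1OC`, differs from compound 1 in one place: 2-(4-fluorophenyl)ethyl in place of 2-(pyridin-3-yl)ethenyl on an aromatic carbon. Going by the values given here, the one measured step, a number 2 percentage points higher from compound 1 to compound 2 (within the scatter), shows that exchanging the ring on the ethenyl chain for another aromatic ring left this assay unchanged; it says nothing about losing the double bond outside aromatic rings, which compound 3 also does. A modest drop, or no step beyond the scatter, is therefore expected, with a wide range. For compound 3 the expected value is 72% (range 40% to 95%), which would be an estimated step of a number 14 percentage points lower from compound 1 to compound 3 (beyond the scatter).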

Compound 3, a percentage reported as inhibition, at one concentration (the size of the read-out at that concentration, not a potency): 69%
Beside the measured number, compound 3's estimate is 3 percentage points above it; low and high end bracket the measured number.
By their numbers in this assay, from the lowest: compound 3; then compounds 1 and 2 (each within the scatter of the next).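

The aromatic carbon carrying these groups is not indifferent to change in this assay: moving to the 2-(4-fluorophenyl)ethyl group gives a number 17 percentage points lower from compound 1 to compound 3 (beyond the scatter) and a number 19 percentage points lower from compound 2 to compound 3 (beyond the scatter), whereas the earlier exchange of the ring on the ethenyl chain stayed within the scatter. The new group differs from both earlier groups in two ways at once, losing the double bond outside aromatic rings and carrying a 4-fluorophenyl ring, and the drop cannot be assigned to either change alone. Nothing available here explains the drop.

From the compounds shown here alone, it remains open whether the saturated chain or the fluorinated ring accounts for the lower number; a 2-(pyridin-3-yl)ethyl group would keep the ring of compound 1 while removing only the double bond. Going by these compounds, how a longer chain, such as 3-phenylpropyl, would fare at this position is also open.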